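A Chloro Substituent on the Aryl Ring of Compound 2

The compounds below may be only part of what the source reports. "The series", "measured", "known", "first", "only" and "open" are said of these compounds alone.

Of the compounds shown here, two sharing one core have been measured in an assay on isolated protein for inhibition of vitamin D3 receptor (Homo sapiens); a lower number here means a stronger inhibitor, a higher number a weaker inhibitor. Compound 1 `Cc1ccc(-c2csc(=N)n2CC(=O)N2CCN(c3ccccc3)CC2)cc1` gives 1030 nM, and compound 2 `N=c1scc(-c2ccccc2)n1CC(=O)N1CCN(c2ccccc2)CC1` gives 1600 nM. Compound 2 thus holds the higher of the two numbers, but the step of a 1.6-fold higher number from compound 1 to compound 2 (0.19 log units; within the scatter) is within the scatter, so the two compounds cannot be told apart in this assay. The unmeasured compound 3 `N=c1scc(-c2ccc(Cl)cc2)n1CC(=O)N1CCN(c2ccccc2)CC1` differs from compound 2 by chloro in place of hydrogen on an aromatic carbon of a six-membered aromatic ring of carbon only, para to a large group; cut one bond further out, the difference reads phenyl to 4-chlorophenyl. For the measured compounds named here, the only measured step at that aromatic carbon is a 1.6-fold higher number from compound 1 to compound 2 (0.19 log units; within the scatter), which concerns a different group and stayed within the scatter. Going by the values given here, no measured step involves chloro. On this basis compound 3 is expected to land near compound 2 in this assay. The expected step is a 1.5-fold lower number from compound 2 to compound 3 (0.16 log units; within the scatter), which need not exceed the scatter. Compound 3 is estimated at 1100 nM, with a range from 400 nM to 3000 nM.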

Compound 3, inhibition constant: 3070 nM
Compound 3: middle estimate off by 2.8-fold (0.45 log units), on the low side, and the stated range ends below it.
By their numbers in this assay, from the lowest: compounds 1, 2 and 3 (each within the scatter of the next, the first and the last beyond it).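

For the compounds shown here, at this aromatic carbon, para to a large group, chloro and methyl can now be compared directly in this assay as the change shows a 3.0-fold higher number from compound 1 to compound 3 (0.47 log units; beyond the scatter) and this modest step is the only one among the three compounds that lies beyond the scatter. The phenyl to 4-chlorophenyl change on its own gives a 1.9-fold higher number from compound 2 to compound 3 (0.28 log units; within the scatter) and so does not separate chloro from hydrogen, just as hydrogen was not separated from methyl earlier; the position therefore distinguishes only its two substituted forms, with the unsubstituted compound 2 resolved from neither. No measurement available here explains why chloro and methyl differ at this position.

Going by these compounds alone, what remains open is whether this separation reflects something general about the position or only this one pair, since a single modest step rests on compound 1 and compound 3 alone. A methoxy group, an amine or a carboxylic acid at the same aromatic carbon would show whether the numbers can move further in either direction than these three compounds do.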